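Swapping an Iodophenyl for a Hydroxyphenyl: Cytotoxicity Outlook

A few compounds are considered here, and "the series" means these few. Any claim that something is new, unique, unknown or untested is made for them only; others in the source may bear on it.

Measured so far:
compound 1, `O=C(/C=C/c1ccc2c(c1)B(O)OC2)c1ccc(O)c(O)c1`, > 10 ug/mL
compound 2, `O=C(/C=C/c1ccc2c(c1)B(O)OC2)c1ccc(I)cc1`, > 10 ug/mL

Within the data shown here, both compounds have been tested in an ADME assay on L929 cells (Mus musculus) for cytotoxicity, read by resazurin assay, with a stated time of 72 h; a higher number here means a weaker inhibitor, a lower number a stronger inhibitor. Compound 1 reaches only a limit of the assay, > 10 ug/mL, not a number. Compound 2 likewise reaches only a limit, > 10 ug/mL. So compound 2 stands at the edge of what the assay reports, and the limit of > 10 ug/mL in this assay, at which 2 of the 2 values shown sit, shows that nothing measured here has fallen below that edge.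

Compound 3, `O=C(/C=C/c1ccc2c(c1)B(O)OC2)c1cccc(O)c1`, has not yet been measured. It differs from compound 2 in one place: 3-hydroxyphenyl in place of 4-iodophenyl on a carbonyl carbon.

Since neither measured compound gave a number in this assay, no step size is known. The expected step that the limit leaves unreadable from compound 2 to compound 3 is none beyond the usual scatter, with compound 3 most likely staying at the limit. For compound 3 the estimate is 15 ug/mL, between 7 ug/mL and 40 ug/mL.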

Compound 3, half-maximal inhibitory concentration: 7.56 ug/mL
The estimate for compound 3 lay 2.0-fold (0.30 log units) above the measured number, and the stated range covers the measured number.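

In this assay, compound 3 is the first of these compounds to give a number rather than a limit, so changes at the group on the carbonyl carbon can produce a readable result. Two single changes lead to it: 3-hydroxyphenyl in place of 4-iodophenyl gives an at least 1.3-fold lower number from compound 2 to compound 3 (0.12 log units; that floor lies within the scatter), and hydrogen in place of hydroxy on an aromatic carbon gives an at least 1.3-fold lower number from compound 1 to compound 3 (0.12 log units; that floor lies within the scatter). Both steps are only floors, so their true sizes stay hidden, and neither can be called a real change, because the starting compounds sit at an edge: the limit of > 10 ug/mL in this assay, at which 2 of the 3 values shown sit.

The compounds shown leave open what actual numbers compound 1 and compound 2 would give. They also leave open how an amine or a carboxylic acid on the same phenyl ring would read.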